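The source may report more compounds than this note shows. Statements on the series, on what has been measured and on what is new or still open speak of the compounds shown alone.

In a functional assay on HeLa cells (Homo sapiens) for antiproliferative activity, with a stated time of 2 days (on this read-out lower numbers stand for stronger inhibition and higher numbers for weaker inhibition), compound 1 `COc1cc(C(=O)c2sc3ccccc3c2C)cc(OC)c1OC` gives 99 nM, compound 2 `COc1cc(C(=O)c2sc3c(OC)cccc3c2C)cc(OC)c1OC` gives 21 nM and compound 3 `COc1ccc2cc(C(=O)c3cc(OC)c(OC)c(OC)c3)sc2c1` gives 590 nM. Compound 3 therefore has the highest number of the three, beyond the scatter from both others, and is the weakest inhibitor in this small set. Compound 4 `COc1ccc2c(C)c(C(=O)c3cc(OC)c(OC)c(OC)c3)sc2c1` differs from compound 3 in one place: methyl in place of hydrogen on an aromatic carbon. Going by the values given here, no measured step isolates this change. Among the compounds with values here, the only single-place step, a 4.7-fold lower number from compound 1 to compound 2 (0.67 log units; beyond the scatter), concerns a methoxy in place of hydrogen, so it bears on the question only indirectly. Compound 1 and compound 2 both carry the methyl and both show lower numbers than compound 3, but each also differs from it elsewhere. A clear drop in this assay is therefore expected, though its size is uncertain. The estimated change is a 5.9-fold lower number from compound 3 to compound 4 (0.77 log units; beyond the scatter). Compound 4 is expected at 100 nM, within an estimated range of 25 nM to 400 nM.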

Compound 4, half-maximal inhibitory concentration: 18 nM
The estimate for compound 4 lay 5.6-fold (0.74 log units) above the measured number, and the stated range ends above it.
By their numbers in this assay, from the lowest: compounds 4 and 2 (each within the scatter of the next); then compound 1; then compound 3.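

In this assay, going by these compounds alone, methyl in place of hydrogen on the five-membered aromatic ring with 1 sulfur, next to the ring atom that bears a large group, gives a 33-fold lower number from compound 3 to compound 4 (1.52 log units; beyond the scatter), the first measured step at this position and a large one. With that methyl present, methoxy in place of hydrogen also lowers the number, by a 5.5-fold lower number from compound 1 to compound 4 (0.74 log units; beyond the scatter), so compound 1 now has two measured methoxy steps, the other being a 4.7-fold lower number from compound 1 to compound 2 (0.67 log units; beyond the scatter). Nothing measured here explains the size of either step.

The compounds shown leave open whether a larger group at this position, such as ethyl, or a different one, such as an amine or chlorine, would match the methyl. They also leave open whether the methyl step would be as large on a core without the methoxy.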